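This account rests on a few compounds, and the source may have more. Where it says the series, first, only, none or still open, it means among the compounds named here.

Within the data shown here, in a functional assay on T47D cells (Homo sapiens) for inhibition, read by MTT assay, with a stated time of 48 h (on this read-out lower numbers stand for stronger inhibition and higher numbers for weaker inhibition), two compounds sharing one core have numbers so far. Compound 1 `CCOC(=O)c1c(N)sc(/N=C/c2ccc(OC)cc2)c1C(=O)OCC`, which carries 4-methoxyphenyl on a carbon with a double bond to nitrogen, gives 31900 nM. Compound 2 `CCOC(=O)c1c(N)sc(/N=C/c2ccncc2)c1C(=O)OCC`, which carries pyridin-4-yl at that place, gives 8600 nM, the lower of the two numbers. Compound 3 `CCOC(=O)c1c(N)sc(/N=C/c2ccc(C)cc2)c1C(=O)OCC` has yet to be measured in this assay. It has 4-methylphenyl in place of pyridin-4-yl on the same carbon: 4-methylphenyl in place of pyridin-4-yl on a carbon with a double bond to nitrogen. Among the measured compounds shown here, only one measured step bears on this change, namely a 3.7-fold lower number from compound 1 to compound 2 (0.57 log units; beyond the scatter). That step, modest in size but beyond the scatter, went from a substituted carbon-only ring to pyridin-4-yl, and the new change runs the opposite way. A step towards a higher number is therefore expected, of similar or somewhat smaller size, since 4-methylphenyl is not the group of compound 1 and a single step is thin evidence. The estimate thus expects a 2.6-fold higher number from compound 2 to compound 3 (0.41 log units; beyond the scatter). For compound 3 the expected value is 22000 nM, with an estimated range from 9000 nM to 52000 nM.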

Compound 3, half-maximal inhibitory concentration: 37200 nM
The estimate for compound 3 lay 1.7-fold (0.23 log units) below the measured number; the range from low to high includes it.
By their numbers in this assay, from the lowest: compound 2; then compounds 1 and 3 (each within the scatter of the next).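

Read in this assay the move from pyridin-4-yl to 4-methylphenyl gives a 4.3-fold higher number from compound 2 to compound 3 (0.64 log units; beyond the scatter) and thus shows that the earlier gap was not peculiar to the 4-methoxyphenyl of compound 1: both carbon-only rings on this carbon, in compound 1 and compound 3, stand at higher numbers than the pyridin-4-yl of compound 2, and neither of the three goes against this. Methyl in place of methoxy on an aromatic carbon yields a 1.2-fold higher number from compound 1 to compound 3 (0.07 log units; within the scatter) so the choice between these two substituents makes no readable difference here, and the gap to compound 2 appears with either of them. Nothing measured on these compounds explains the size of either step.

The compounds shown leave open whether the lower number of compound 2 goes with the ring nitrogen itself or with the lack of any substituent on the ring, a question on which plain phenyl and pyridin-3-yl would bear. They also leave open whether a substituent of another kind on the carbon-only ring, such as a dimethylamino group or a carboxylic acid, would stay with methyl and methoxy or move towards compound 2.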